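The compounds below may be only part of what the source reports. "The series", "measured", "known", "first", "only" and "open" are said of these compounds alone.

Measured so far:
- compound 1, `CCNc1nc(Cl)nc(N[C@H](C)c2ccccc2)n1`: 2690 nM
- compound 2, `CC[C@H](C)Nc1nc(Cl)nc(N[C@@H](C)c2ccccc2)n1`: 14100 nM
- compound 3, `CC[C@@H](C)Nc1nc(Cl)nc(N[C@H](C)c2ccccc2)n1`: 4570 nM

In an ADME assay on the whole organism for inhibition, with Echinochloa crus-galli var. formosensis as the target, with a stated time of 4 days (on this read-out lower numbers stand for stronger inhibition and higher numbers for weaker inhibition), compound 2 gives the highest of the three numbers; the nearest is compound 3 and the furthest is compound 1, both beyond the scatter. Compound 3 and compound 2 are mirror images, and that inversion alone shifts the read-out by a 3.1-fold lower number from compound 2 to compound 3 (0.49 log units; beyond the scatter), a modest step that follows from the fact that compounds 2 and 3 differ only in the configuration as drawn. Adding ethyl in place of hydrogen on the saturated chain carbon bound to the ring nitrogen gives a 1.7-fold higher number from compound 1 to compound 3 (0.23 log units; within the scatter), within the scatter.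

Compound 4, `CCCN(C)c1nc(Cl)nc(N[C@@H](C)c2ccccc2)n1`, is not yet measured. It differs from compound 2 by methyl(propyl)amino in place of (sec-butyl)amino on an aromatic carbon. Neither measured step covers this change: the donor hydrogen is removed and the stereocentre of the entering group disappears, while the other stereocentre keeps the configuration drawn in compound 2, the weaker of the two mirror images. For the measured compounds named here, no measured step in this set reports a loss of the donor, so the direction rests on compound 2 alone as the starting point.

Compound 4 is expected to give a number somewhat higher than compound 2, a step of roughly a 2.1-fold higher number from compound 2 to compound 4 (0.33 log units; beyond the scatter). Compound 4 is therefore estimated at 30000 nM, with a range from 9000 nM to 100000 nM.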

Compound 4, half-maximal inhibitory concentration: 380 nM
Compound 4: the middle estimate sits 79-fold (1.90 log units) above what was measured; measured number below the stated range.
By their numbers in this assay, from the lowest: compound 4; then compounds 1 and 3 (each within the scatter of the next); then compound 2.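

Notes on the position between two ring nitrogen atoms: in this assay, replacing (sec-butyl)amino with methyl(propyl)amino, which has the same heavy-atom count, gives a 37-fold lower number from compound 2 to compound 4 (1.57 log units; beyond the scatter), whereas the earlier step at this place, a 1.7-fold higher number from compound 1 to compound 3 (0.23 log units; within the scatter), stayed within the scatter and the mirror-image step, a 3.1-fold lower number from compound 2 to compound 3 (0.49 log units; beyond the scatter), was only modest. For the compounds shown here, the series therefore responds far more strongly to how these atoms are joined than the earlier compounds showed, and compound 4 reaches 380 nM while keeping the remaining stereocentre as drawn in compound 2, the higher-numbered of the two mirror images. Nothing on hand bears on a cause for this step.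

The change removes the amino hydrogen, removes a stereocentre and replaces a branched chain with a methyl and a propyl group all at once, so the compounds shown do not assign the step to any one of these. A methyl(sec-butyl)amino group or a propylamino group at this place would separate these changes, and the mirror image of compound 4 leaves the role of the remaining stereocentre open.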